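The compounds below may be only part of what the source reports. "The series", "measured", "known", "first", "only" and "open" are said of these compounds alone.

Measured so far:
Compound 1 `Cc1nc(-c2ccccc2NCC2=NCCN2)cs1`: in a functional assay for activation of Alpha-1D adrenergic receptor (Homo sapiens) (on this read-out higher numbers stand for an effect only at larger amounts of compound and lower numbers for an effect already at smaller amounts), compound 1 gives only a limit, < 5020 nM.
Compound 2 `c1ccc(-c2ccccc2NCC2=NCCN2)nc1`: in this assay compound 2 gives 41.7 nM.

Within the data shown here, compound 2 thus carries the only measured number; the other value shown is a limit. The step from compound 1 to compound 2, a step that the limit leaves unreadable from compound 1 to compound 2, cannot be sized because the value of compound 1 is the limit of < 5020 nM in this assay, at which 1 of the 2 values shown sits.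

Compound 3 `c1cnc(-c2ccccc2NCC2=NCCN2)nc1` has not yet been measured. It differs from compound 2 in one place: pyrimidin-2-yl in place of pyridin-2-yl on an aromatic carbon. No measured step concerns this exchange, and the single step shown swaps a different ring and is unreadable, so nothing points to a shift in either direction. The expected step is a 1.4-fold higher number from compound 2 to compound 3 (0.16 log units; within the scatter), within the usual scatter. Compound 3 is therefore estimated at 60 nM, with a range from 15 nM to 250 nM.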

Compound 3, half-maximal effective concentration: 81.3 nM
The estimate for compound 3 lay 1.4-fold (0.13 log units) below the measured number, within the range that was stated.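

In this assay, among these compounds, pyrimidin-2-yl in place of pyridin-2-yl on an aromatic carbon gives a 1.9-fold higher number from compound 2 to compound 3 (0.29 log units; within the scatter), the first step at this position that can be read. A six-membered aromatic ring with 2 hetero atoms therefore cannot be told apart from one with 1 hetero atom here, even though the hydrogen-bond acceptor count also rises from 1 to 2. The steps from compound 1 to compound 2 and to compound 3 cannot be read because compound 1 gives only a limit: the limit of < 5020 nM in this assay, at which 1 of the 3 values shown sits.

Still open, from the compounds shown here alone, is whether this position needs a ring nitrogen at all, which a plain phenyl ring would test. Also open, going by these compounds, is how either ring would respond to a small added group such as a methoxy group or an amine.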